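From cyano to sulfanylmethyl on the shared core

The compounds below may be only part of what the source reports. "The series", "measured", "known", "first", "only" and "open" are said of these compounds alone.

In a functional assay (aorta) for inhibition, with Rattus norvegicus as the target (a lower number here means a stronger inhibitor, a higher number a weaker inhibitor), compound 1 `CC/N=C(\S)[C@]1(c2cccnc2)CCCC[S+]1[O-]` gives 300 nM. Compound 2 `N#C[C@]1(c2cccnc2)CCCC[S+]1[O-]` reaches only a limit of the assay, > 30000 nM. Among the compounds with values here, the one measured step bearing on the next change is large: an at least 100-fold higher number from compound 1 to compound 2 (2.00 log units; beyond the scatter). Compound 3 `[O-][S+]1CCCC[C@]1(CS)c1cccnc1` carries sulfanylmethyl in place of cyano on a saturated ring carbon. The entering group holds a sulfur, as the larger group of compound 1 at 300 nM does, so only a partial return towards that value is expected in this assay, with a lower number. The expected step is an at least 3.7-fold lower number from compound 2 to compound 3 (0.57 log units; beyond the scatter). For compound 3 the estimated value is 8000 nM, within a range of 1000 nM to 30000 nM.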

Compound 3, concentration for 90% inhibition: > 30000 nM
Compound 3: only a limit was reported; the forecaster's own chance of this, stated with the estimate: 40%; at least 3.7-fold (0.57 log units) between middle value and limit.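

Holding a sulfur in the group on this saturated ring carbon is not enough in this assay: putting sulfanylmethyl in place of the larger group gives an at least 100-fold higher number from compound 1 to compound 3 (2.00 log units; beyond the scatter). A hydrogen-bond donor in the small entering group does not bring the value within the range of the assay either. The step from compound 2 to compound 3 cannot be read, since both compounds stop at the same limit: the limit of > 30000 nM in this assay, at which 2 of the 3 values shown sit.

On these data alone, it stays open which part of the larger group of compound 1 carries its activity. An aminomethyl group or a longer chain ending in sulfanyl on this carbon could begin to answer that.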